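The source may hold more compounds than are shown below. What is called first, only, known or untested is meant among the compounds shown, and "the series" means these compounds.

Measured so far:
compound 1 `CC1=C(/C=C/C(=O)/C=C/c2ccc(C#N)cc2)C(C)(C)CCC1` in a functional assay on HeLa cells (Homo sapiens) for cytotoxicity, read by sulforhodamine B assay, with a stated time of 48 h; a lower number here means a stronger inhibitor, a higher number a weaker inhibitor: 22200 nM
compound 2 `CC1=C(/C=C/C(=O)/C=C/C=C/c2ccccc2)C(C)(C)CCC1` in this assay: > 100000 nM

For compound 2 the value in this assay is a limit of the assay and not a number (the limit of > 100000 nM in this assay, at which 1 of the 2 values shown sits). Among the compounds with values here, compound 2 thus stands at the weak end of the two values shown, and no step between measured compounds is available that would set the size of any change on the aryl ring. Within the data shown here, compound 1 is the only compound here with a numeric value.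

The unmeasured compound 3 `COc1ccccc1/C=C/C=C/C(=O)/C=C/C1=C(C)CCCC1(C)C` differs from compound 2 in one place: methoxy in place of hydrogen on an aromatic carbon. The dienone linker and the shared core of compound 2 are kept. Among the measured compounds shown here, with no measured step on this or any other part of the series, the size of the change is open; the expectation is for no step beyond the scatter in this assay, so the step from compound 2 to compound 3 is estimated as a number no higher from compound 2 to compound 3 (the limit leaves the size open). Compound 3 is accordingly expected at 100000 nM, with a range from 35000 nM to 300000 nM, and most likely reported as a limit again.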

Compound 3, half-maximal inhibitory concentration: 33500 nM
Estimate against measurement, compound 3: 3.0-fold (0.47 log units) above, and the stated range ends above it.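

In this assay, within the data shown here, methoxy in place of hydrogen on an aromatic carbon, ortho to a large group, gives an at least 2.9-fold lower number from compound 2 to compound 3 (0.47 log units; beyond the scatter), the first step that can be read. The aryl ring therefore responds to substitution at this position: with the dienone linker and shared core kept, the change from phenyl to 2-methoxyphenyl brings compound 3 to a numeric value of 33500 nM. The true size of the step remains unknown because the value of compound 2 is a limit of the assay, so the step gives only a minimum: the limit of > 100000 nM in this assay, at which 1 of the 3 values shown sits.

Open, on these data alone, is whether the change belongs to methoxy itself or would follow from other groups on the same carbon, such as a hydroxyl, a fluorine or a dimethylamino group, and whether methoxy elsewhere on the ring would give a like step. Compound 1 differs from compound 3 in both linker and aryl substituent, which leaves the separate contributions of its nitrile and shorter linker unresolved.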